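Chloro to bromo swap on the ester aryl group

A few compounds are considered here, and "the series" means these few. Any claim that something is new, unique, unknown or untested is made for them only; others in the source may bear on it.

Measured so far:
Compound 1, `CC(=O)OCc1ccc2oc(=O)c(C(=O)Oc3cccc(Br)c3)cc2c1`: 21.8%
Compound 2, `NCc1ccc2oc(=O)c(C(=O)Oc3cccc(Br)c3)cc2c1`: 79.3%
Compound 3, `CC(=O)NCc1ccc2oc(=O)c(C(=O)Oc3cccc(Cl)c3)cc2c1`: 36.6%

In a functional assay on HT-1080 cells (Homo sapiens), read by transwell migration, with a stated time of 24 h, tested at 1 uM (a higher number here means a weaker effect of the compound at the concentration tested, a lower number a stronger effect), compound 3 gives 36.6% and stands second highest of the three numbers. Its nearest neighbour is compound 1 with 21.8%, a number beyond the scatter lower; the furthest is compound 2 with 79.3%, a number beyond the scatter higher. Among the compounds with values here, the one step computed between measured compounds, a number 57.5 percentage points higher from compound 1 to compound 2 (beyond the scatter), concerns a change on the saturated chain carbon bound to the aromatic carbon and is large.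

Compound 4, `CC(=O)NCc1ccc2oc(=O)c(C(=O)Oc3cccc(Br)c3)cc2c1`, is not yet measured. It differs from compound 3 as follows: bromo in place of chloro on an aromatic carbon. Within the data shown here, no measured step touches this halogen exchange; the step from compound 1 to compound 2 lies in a different part of the molecule and gives no guidance on it. Compound 1 and compound 2 both carry bromo, compound 3 carries chloro, but nothing in the numbers separates the halogen from the other change. Among the measured compounds shown here, with no step bearing on it, the expected change in this assay is none beyond the scatter, in either direction, and the estimated step is a number 1.6 percentage points lower from compound 3 to compound 4 (within the scatter). Compound 4 is therefore expected to give about 35% in this assay, in the range 20% to 52%.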

Compound 4, a percentage reported as activity, at one concentration (the size of the read-out at that concentration, not a potency): 36.9%
Estimate against measurement, compound 4: 1.9 percentage points below; the range from low to high includes it.
By their numbers in this assay, from the lowest: compound 1; then compounds 3 and 4 (each within the scatter of the next); then compound 2.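

In this assay, the exchange of 3-chlorophenyl for 3-bromophenyl on the ester can now be read on its own: a number 0.3 percentage points higher from compound 3 to compound 4 (within the scatter), so with the acetamido side chain this halogen exchange leaves the read-out within the scatter. Compound 4 also adds a third side chain to the bromo compounds, and a number 42.4 percentage points lower from compound 2 to compound 4 (beyond the scatter), a large move towards a stronger effect with acetyl on the amine nitrogen, while a number 15.1 percentage points higher from compound 1 to compound 4 (beyond the scatter), a modest move towards a weaker effect with acetamido in place of acetoxy. Within the data shown here, with bromo held fixed, the read-out in these three compounds follows the group on the saturated chain carbon, whereas the single halogen pair shows no change beyond the scatter.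

Among these compounds, the halogen exchange is seen only with the acetamido side chain, so its size with the amine or the acetoxy group stays open, as does the outcome with a methoxy group or a nitrile in place of the halogen, or a propionyl group in place of acetyl on the amine nitrogen. The data at hand offer no explanation for any of these steps.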